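The compounds below may be only part of what the source reports. "The series", "measured", "known", "first", "only" and "open" are said of these compounds alone.

Measured compounds in this set:
- compound 1 `O=C(Nc1cccc(-n2cc(-c3ccncc3)c(-c3cc(O)cc(Cl)c3)n2)c1)Nc1ccc(Cl)c(C(F)(F)F)c1`: -52%
- compound 2 `O=C(Nc1cccc(-n2cc(-c3ccncc3)c(-c3cc(O)cc(Cl)c3)n2)c1)Nc1ccc(Cl)c(Cl)c1`: -48%

In a functional assay on NCI-H460 cells (Homo sapiens) for inhibition, read by sulforhodamine B assay, with a stated time of 48 h, tested at 100 uM (a higher number here means a weaker effect of the compound at the concentration tested, a lower number a stronger effect), compound 1 gives -52%, the lower of the two numbers recorded. Compound 2 gives -48% in this assay, and the step of a number 4 percentage points higher from compound 1 to compound 2 (within the scatter) lies within the scatter, so the two compounds stand level on the data available.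

Compound 3 `COc1cc(Cl)cc(-c2nn(-c3cccc(NC(=O)Nc4ccc(Cl)c(C(F)(F)F)c4)c3)cc2-c2ccncc2)c1` has not yet been measured in this assay. Compared with compound 1 the change is methyl in place of hydrogen on an oxygen on an aromatic ring. Within the data shown here, no measured step bears on this position: the only step known, from compound 1 to compound 2, concerns a different change, chloro in place of trifluoromethyl on an aromatic carbon, and was within the scatter. An expectation for compound 3 therefore rests on the value of compound 1 alone, with a wide range. Compound 3 is expected to give about -45% in this assay, between -75% and -5%. This estimate means a step of a number 7 percentage points higher from compound 1 to compound 3 (within the scatter), which is expected to stay close to the scatter.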

Compound 3, a percentage reported as activity, at one concentration (the size of the read-out at that concentration, not a potency): -62%
Compound 3: the middle estimate sits 17 percentage points above what was measured; low and high end bracket the measured number.
By their numbers in this assay, from the lowest: compounds 3, 1 and 2 (each within the scatter of the next, the first and the last beyond it).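

In this assay the hydroxy to methoxy change, the first change read at this position, gives a number 10 percentage points lower from compound 1 to compound 3 (within the scatter) and so leaves compound 3 level with compound 1. Methyl on this oxygen is therefore tolerated in the 3-chloro-5-methoxyphenyl compound, and the hydrogen of the hydroxy group is not needed for the read-out at the concentration tested, at least alongside the trifluoromethyl of compound 1. No supporting measurement is available to explain this result.

From the compounds shown here alone, it remains open whether a longer chain on this oxygen, such as ethoxy, or an amine in place of the hydroxy group, would also stay level. Going by these compounds, it is equally open whether the same methyl step would read alike on compound 2, which carries chloro in place of trifluoromethyl.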